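Growing the alkyl group on the shared core

This account rests on a few compounds, and the source may have more. Where it says the series, first, only, none or still open, it means among the compounds named here.

Compound 1 `Cc1ccc(S(=O)(=O)Nc2ccc(O)cc2)cc1` carries a methyl group on the shared core. In an assay on HepG2 cells for inhibition of cytochrome b-c1 complex subunit 7 (Homo sapiens), read by Western blot, with a stated time of 4 h (a lower number here means a stronger inhibitor, a higher number a weaker inhibitor), compound 1 gives > 20000 nM, which is a limit of the assay. Compound 2 `CCc1ccc(S(=O)(=O)Nc2ccc(O)cc2)cc1` carries an ethyl group instead. In this assay compound 2 gives > 20000 nM, again a limit. The step that the two limits leave unreadable from compound 1 to compound 2 is thus unreadable, and compound 2 stands at the limit of > 20000 nM in this assay, at which 2 of the 2 values shown sit. Compound 3 `CC(C)(C)c1ccc(S(=O)(=O)Nc2ccc(O)cc2)cc1` differs from compound 2 by tert-butyl in place of ethyl on an aromatic carbon. Within the data shown here, no measured step reads on this change, so compound 3 is expected to stay at or beyond the same limit, with an expected step that the limit leaves unreadable from compound 2 to compound 3. Compound 3 is estimated at 30000 nM, between 10000 nM and 100000 nM.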

Compound 3, half-maximal inhibitory concentration: 5000 nM
The estimate for compound 3 lay 6.0-fold (0.78 log units) above the measured number; measured number outside the range, below it.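

In this assay, among these compounds, tert-butyl on this aromatic carbon gives the first value that is a number and not a limit, with an at least 4.0-fold lower number from compound 2 to compound 3 (0.60 log units; beyond the scatter) and an at least 4.0-fold lower number from compound 1 to compound 3 (0.60 log units; beyond the scatter). Both steps are lower bounds, so their full size cannot be read. Methyl and ethyl did not move the series off the limit, while tert-butyl did: the limit of > 20000 nM in this assay, at which 2 of the 3 values shown sit.

Still open, going by these compounds, is whether an isopropyl group or a straight butyl chain at this place would match compound 3. That would separate branching from carbon count as the feature tracking this step.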